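Amino in place of methylcarbamoyl on the benzylamine ring

A few compounds are considered here, and "the series" means these few. Any claim that something is new, unique, unknown or untested is made for them only; others in the source may bear on it.

Compound 1 `O=[N+]([O-])c1cccc(CNc2cc(C(F)(F)F)cc3[nH]ncc23)c1` gives 5170 nM in an assay for inhibition of Tryptophan 2,3-dioxygenase (Homo sapiens), with stated times of 10 min and 60 min; a lower number here means a stronger inhibitor, a higher number a weaker inhibitor. Compound 2 `OC1CCCC(Nc2cccc(CNc3cc(C(F)(F)F)cc4[nH]ncc34)c2)C1` reaches only a limit of this assay, > 100000 nM. Compound 3 `CNC(=O)c1cccc(CNc2cc(C(F)(F)F)cc3[nH]ncc23)c1` gives 4870 nM.

On these numbers compound 3 sits with compound 1; the two differ only within the scatter, as a 1.1-fold lower number from compound 1 to compound 3 (0.03 log units; within the scatter) shows, while compound 2 sits at a limit. Compound 4 `Nc1cccc(CNc2cc(C(F)(F)F)cc3[nH]ncc23)c1` differs from compound 3 by amino in place of methylcarbamoyl on an aromatic carbon. Going by the values given here, two measured steps bear on this position: a 1.1-fold lower number from compound 1 to compound 3 (0.03 log units; within the scatter) is small, whereas an at least 20-fold lower number from compound 2 to compound 3 (1.31 log units; beyond the scatter) is large, with the bulky group at that position giving the weaker compound. The amino group is the smallest substituent yet tried there, so compound 4 is expected to stay within the scatter of compound 3, as a 1.4-fold higher number from compound 3 to compound 4 (0.16 log units; within the scatter). Compound 4 is thus estimated at 7000 nM, between 2000 nM and 30000 nM.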

Compound 4, half-maximal inhibitory concentration: 2510 nM
Beside the measured number, compound 4's estimate is 2.8-fold (0.45 log units) above it; low and high end bracket the measured number.
By their numbers in this assay, from the lowest: compounds 4, 3 and 1 (each within the scatter of the next, the first and the last beyond it). At a limit, above all of these: compound 2.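

In this assay, amino and methylcarbamoyl at this position cannot be told apart, a 1.9-fold lower number from compound 3 to compound 4 (0.29 log units; within the scatter), whereas amino does separate modestly from nitro, a 2.1-fold lower number from compound 1 to compound 4 (0.31 log units; beyond the scatter). Taking the 3-hydroxycyclohexyl off the nitrogen gives a far larger step, an at least 39-fold lower number from compound 2 to compound 4 (1.60 log units; beyond the scatter). That step rests on a limit for compound 2, so its full size cannot be read: the limit of > 100000 nM in this assay, at which 1 of the 4 values shown sits.

Left open is how a group smaller than 3-hydroxycyclohexyl on that nitrogen, such as methyl or acetyl, would fall within this range. Also open, as far as these compounds go, is where a carboxylic acid or a nitrile at this position would stand.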